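The source may hold more compounds than are shown below. What is called first, only, known or untested is meant among the compounds shown, and "the series" means these compounds.

Working notes on the series. In a physicochemical assay for solubility, in phosphate buffer, at pH 7.4 (on this read-out higher numbers stand for higher solubility and lower numbers for lower solubility), compound 1 (`CC(=O)N[C@@H]1CCC[C@H](C(=O)Nc2cc(-c3cnn(C)c3C)c(Cl)cn2)C1`) gives 960000 nM, and compound 2 (`CC(=O)N[C@@H]1CCC[C@H](C(=O)Nc2cc(-c3cnc4n3CCCC4)c(Cl)cn2)C1`) gives 600000 nM. Among the compounds with values here, these are the only two numbers so far, and they lie within the scatter of each other. Compound 2 therefore cannot be separated from compound 1.

Compound 3 (`CC(=O)N[C@@H]1CCC[C@H](C(=O)Nc2cc(-c3cnc(C)n3C)c(Cl)cn2)C1`) keeps the shared core of compound 2 and carries one change: a group of 7 heavy atoms (5 carbon, 2 nitrogen; one five-membered aromatic ring with 2 hetero atoms) in place of a group of 9 heavy atoms (7 carbon, 2 nitrogen; one five-membered aromatic ring with 2 hetero atoms, one six-membered non-aromatic ring with 1 hetero atom), on an aromatic carbon. The entering 1,2-dimethyl-1H-imidazol-5-yl group sits on the same aromatic carbon, ortho to a chloro group.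

Within the data shown here, one measured step bears on this change, namely a 1.6-fold lower number from compound 1 to compound 2 (0.20 log units; within the scatter). It brought in the group that now leaves, in place of a smaller group that also has a five-membered aromatic ring with 2 hetero atoms. Among the measured compounds shown here, that smaller group is not the one entering here, so the step is only a partial guide, and no measured compound yet carries the entering group. Given the small size of that step, no change beyond the scatter is expected in this assay.

The expected step is a 1.3-fold higher number from compound 2 to compound 3 (0.12 log units; within the scatter). Compound 3 is estimated at 800000 nM, with an expected range of 400000 nM to 1500000 nM.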

Compound 3, solubility: > 1000000 nM
Compound 3: only a limit was reported (the forecaster's own chance of this, stated with the estimate: 15%); middle value at least 1.2-fold (0.09 log units) away from the limit.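

In this assay, within the data shown here, compound 3 gives > 1000000 nM, which is a limit and not a number, and it is the first such reading. The two new steps are an at least 1.6-fold higher number from compound 2 to compound 3 (0.22 log units; that floor lies within the scatter) and an at least 1.0-fold higher number from compound 1 to compound 3 (0.01 log units; that floor lies within the scatter), so the 1,2-dimethyl-1H-imidazol-5-yl group on this aromatic carbon, opposite the ring nitrogen, gives no lower number than either earlier group, though both floors stay within the scatter and neither step separates compound 3 from the others. What the earlier compounds did not show is that this read-out can reach a limit with the change at this position, so the steps to compound 3 are floors and not sizes: the limit of > 1000000 nM in this assay, at which 1 of the 3 values shown sits.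

From the compounds shown here alone, how far the true value of compound 3 lies past its limit stays open, and with it whether either step really exceeds the scatter. Also open, going by these compounds, is whether a group of another kind on this aromatic carbon, such as an amine or a carboxylic acid, would give a step beyond the scatter in this assay.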